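This account rests on a few compounds, and the source may have more. Where it says the series, first, only, none or still open, it means among the compounds named here.

Measured compounds in this set:
- compound 1, `O=C(O)CCc1ccc(OCc2ccccc2)c(I)c1`: in a functional assay on 1321-N1 cells for agonist activity at Free fatty acid receptor 1 (Homo sapiens), read by calcium flux (on this read-out lower numbers stand for an effect already at smaller amounts and higher numbers for an effect only at larger amounts of compound), compound 1 gives 12600 nM
- compound 2, `O=C(O)CCc1ccc(C#Cc2ccccc2)cc1`: in this assay compound 2 gives 200 nM
- compound 3, `O=C(O)CCc1ccc(OCc2ccc(Br)cc2)cc1`: in this assay compound 3 gives 550 nM

Compound 3 stands second highest of the three numbers in this assay. Its nearest neighbour is compound 2, whose number is lower by more than the scatter; compound 1 is furthest away, with a much higher number, again beyond the scatter. No two of the measured compounds differ in only one place, so no single structural step can be read off among them; the three values only show that the shared core tolerates quite different groups on the benzyloxy or ethynyl arm, with the iodo-substituted compound 1 clearly weakest.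

Compound 4, `O=C(O)CCc1ccc(OCc2ccc(-c3ccccc3)cc2)cc1`, is not yet measured. It differs from compound 3 by phenyl in place of bromo on an aromatic carbon. Without a measured step of this kind in the set, the expectation rests on the spread between compound 3 and compound 2: a larger carbon-only aromatic extension at the far end of the arm has gone together with the lower number in compound 2. A modest downward step, a 1.8-fold lower number from compound 3 to compound 4 (0.26 log units; within the scatter), is therefore expected from compound 3 to compound 4, possibly not beyond the scatter. For compound 4 the estimate in this assay is 300 nM, with a likely range from 80 nM to 1200 nM.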

Compound 4, half-maximal effective concentration: 912 nM
Compound 4: middle estimate off by 3.0-fold (0.48 log units), on the low side, within the range that was stated.
By their numbers in this assay, from the lowest: compound 2; then compounds 3 and 4 (each within the scatter of the next); then compound 1.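

In this assay, going by these compounds alone, the step of phenyl in place of bromo, on an aromatic carbon para to a large group, gives a 1.7-fold higher number from compound 3 to compound 4 (0.22 log units; within the scatter) and is the only single-place comparison so far. This place on the shared core therefore accepts a whole six-membered aromatic ring of carbon only where compound 3 carries a single bromine, with no difference that can be told from repeated-measurement scatter, so neither of the two groups can be ranked above the other on this read-out. The data at hand give no explanation for this result.

Going by these compounds, what remains open is whether this tolerance extends beyond these two groups, for instance to a hydrogen, a methoxy group, an amine or a carboxylic acid at the same place, any of which would show whether the substituent matters here at all. Also open, on these data alone, is how the oxygen-and-methylene link of the arm compares with an ethynyl link carrying the same end group, and whether a longer chain in that link would keep the values of compound 3 and compound 4.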